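Chloro on the chain of compound 1: a one-atom swap

The compounds below may be only part of what the source reports. "The series", "measured", "known", "first", "only" and "open" are said of these compounds alone.

Compound 1 `CC/C(=C(/c1ccc(/C=C/C(=O)O)cc1)c1ccc2[nH]ncc2c1)c1ccccc1`: 7.2 nM
Compound 2 `CCC/C(=C(/c1ccc(/C=C/C(=O)O)cc1)c1ccc2[nH]ncc2c1)c1ccccc1`: 11 nM

In a functional assay on MCF7 cells (Homo sapiens) for cytotoxicity, read by CellTiter-Glo, with a stated time of 5 days (a lower number here means a stronger inhibitor, a higher number a weaker inhibitor), compound 1 gives 7.2 nM, the lowest of the two numbers, with compound 2 nearest at 11 nM. Compound 3 `O=C(O)/C=C/c1ccc(/C(=C(/CCCl)c2ccccc2)c2ccc3[nH]ncc3c2)cc1` differs from compound 1 by chloro in place of hydrogen on a saturated chain carbon, two bonds along the chain from a double-bonded chain carbon. Among the measured compounds shown here, the one measured step at the same place, a 1.5-fold higher number from compound 1 to compound 2 (0.18 log units; within the scatter), stayed within the scatter, so a step of similar size or none is expected for compound 3. Compound 3 is therefore estimated at 9 nM, between 4 nM and 22 nM, a step of a 1.3-fold higher number from compound 1 to compound 3 (0.10 log units; within the scatter).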

Compound 3, half-maximal inhibitory concentration: 9 nM
The estimate for compound 3 equals the measured number at the digits printed, and the stated range covers the measured number.
By their numbers in this assay, from the lowest: compounds 1, 3 and 2 (each within the scatter of the next).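

In this assay, the change from ethyl to 2-chloroethyl gives a 1.3-fold higher number from compound 1 to compound 3 (0.10 log units; within the scatter), and chloro in place of methyl gives a 1.2-fold lower number from compound 2 to compound 3 (0.09 log units; within the scatter). This position has now taken a chlorine as well as a methyl with no step beyond the scatter, so compound 1, compound 2 and compound 3 cannot be told apart here. No evidence is available that bears on this result.

As far as these compounds go, whether a hydroxyl, an amine or a carboxylic acid at this position would also stay within the scatter remains open, as does the outcome for a longer chain.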